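Swapping the Amide Heteroaryl on a Phenyl Sulfone

The source may hold more compounds than are shown below. What is called first, only, known or untested is meant among the compounds shown, and "the series" means these compounds.

The study measures how much of each compound survives in an ADME assay on microsomes from liver (Mus musculus) for metabolic stability, read by LC-MS, with a stated time of 30 min, tested at 1 uM; a lower number here means that less of the compound is left, a higher number that more of the compound is left. Compound 1 `O=C(NCc1ccc(S(=O)(=O)c2cc(F)cc(F)c2)cc1)c1cc2cnccc2[nH]1` gives 63% there. Compound 2 `O=C(NCc1ccc(S(=O)(=O)c2cc(F)cc(F)c2)cc1)c1cnc2nccn2c1`, which carries the change (a group of 9 heavy atoms (6 carbon, 3 nitrogen; one five-membered aromatic ring with 2 hetero atoms, one six-membered aromatic ring with 2 hetero atoms) in place of a group of 9 heavy atoms (7 carbon, 2 nitrogen; one five-membered aromatic ring with 1 hetero atom, one six-membered aromatic ring with 1 hetero atom), on a carbonyl carbon), gives 71%; the step is a number 8 percentage points higher from compound 1 to compound 2 (within the scatter). Compound 3 `O=C(NCc1ccc(S(=O)(=O)c2ccccc2)cc1)c1cc2cnccc2[nH]1` differs from compound 1 by phenyl in place of 3,5-difluorophenyl on a sulfonyl sulfur. Compound 3 gives 54%, with a step of a number 9 percentage points lower from compound 1 to compound 3 (within the scatter). Compound 3 therefore has the lowest of the three numbers, yet its nearest neighbour, compound 1, lies within the scatter of it, and only compound 2 stands beyond the scatter above it.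

Compound 4 `O=C(NCc1ccc(S(=O)(=O)c2ccccc2)cc1)c1cnc2nccn2c1` has not been measured in this assay. It arises from compound 3 through (a group of 9 heavy atoms (6 carbon, 3 nitrogen; one five-membered aromatic ring with 2 hetero atoms, one six-membered aromatic ring with 2 hetero atoms) in place of a group of 9 heavy atoms (7 carbon, 2 nitrogen; one five-membered aromatic ring with 1 hetero atom, one six-membered aromatic ring with 1 hetero atom), on a carbonyl carbon), and this is the same change that leads from compound 1 to compound 2, occurring twice among the four compounds and at a place described in the same words both times. The two cores, that of compound 1 and that of compound 3, differ by phenyl in place of 3,5-difluorophenyl on a sulfonyl sulfur.

Among the measured compounds shown here, on this footing the author expects the change to move compound 4 by about a number 8 percentage points higher from compound 3 to compound 4 (within the scatter), a step of similar size to the earlier a number 8 percentage points higher from compound 1 to compound 2 (within the scatter), which rests on the single measured pair alone. For compound 4 the estimated value is 62%, expected to fall between 48% and 76%, with the measured result of compound 3 as the point of departure.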

Compound 4, percent of the compound remaining: 30%
Estimate against measurement, compound 4: 32 percentage points above, and the stated range ends above it.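

On the core of compound 3, the heteroaryl exchange on the carbonyl carbon gives a number 24 percentage points lower from compound 3 to compound 4 (beyond the scatter), so in this assay the change does not carry over from the core of compound 1: the same change on two cores in this assay, a number 8 percentage points higher (within the scatter) from compound 1 to compound 2 and a number 24 percentage points lower (beyond the scatter) from compound 3 to compound 4, 32 percentage points apart, beyond the scatter of two such steps Read the other way, phenyl in place of 3,5-difluorophenyl on the sulfonyl sulfur gives a number 41 percentage points lower from compound 2 to compound 4 (beyond the scatter), and the size of this step also depends on which heteroaryl group is present: the same change on two cores in this assay, a number 9 percentage points lower (within the scatter) from compound 1 to compound 3 and a number 41 percentage points lower (beyond the scatter) from compound 2 to compound 4, 32 percentage points apart, beyond the scatter of two such steps The two changes therefore do not act independently in these four compounds, but this rests on one set of four and does not show why the outcome depends on the core, or whether the same would hold on any other core.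

The compounds shown leave open how the entering group would behave with a chloro or methoxy group on the phenyl ring in place of the fluorines. They also leave open whether an amine or a longer chain on the carbonyl carbon would depend on the sulfone's aryl group in the same way.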